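This account rests on a few compounds, and the source may have more. Where it says the series, first, only, none or still open, it means among the compounds named here.

Working notes on the series. Compound 1 is `O=C(CSc1nc(Nc2ccccc2)c2ccccc2n1)Nc1cccc(F)c1`, compound 2 is `CCc1ccc(NC(=O)CSc2nc(Nc3ccccc3)c3ccccc3n2)cc1` and compound 3 is `C=CC(=O)Nc1cccc(NC(=O)CSc2nc(Nc3ccccc3C)c3ccccc3n2)c1`; all three share one core and differ only in the two aryl groups. In a functional assay on MDA-MB-231 cells (Homo sapiens) for inhibition, read by MTT assay, with a stated time of 72 h (on this read-out lower numbers stand for stronger inhibition and higher numbers for weaker inhibition), compound 1 reaches only the limit of the assay, > 50000 nM, and gives no number. Compound 2 gives 33900 nM in this assay. Compound 3 gives 20400 nM in this assay, the lowest of the two numbers available, though compound 2 sits within the usual scatter of it, so no order between the two can be read.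

Compound 4 is `C=CC(=O)Nc1cccc(NC(=O)CSc2nc(Nc3cccc(OC)c3)c3ccccc3n2)c1`. It differs from compound 3 by 3-methoxyphenyl in place of 2-methylphenyl on a nitrogen on an aromatic ring. Going by the values given here, the only measured step, an at least 1.4-fold lower number from compound 1 to compound 2 (0.16 log units; that floor lies within the scatter), alters the aryl on the amide-type nitrogen and not the aryl on the ring nitrogen, and its floor lies within the scatter, so it gives no guide for the present change. With nothing measured on this position, no step beyond the scatter is expected, a 1.0-fold lower number from compound 3 to compound 4 (0.01 log units; within the scatter). Compound 4 is therefore estimated at 20000 nM, within 7000 nM to 50000 nM. A limit rather than a number remains possible, as the limit of > 50000 nM in this assay, at which 1 of the 3 values shown sits, shows for this series.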

Compound 4, half-maximal inhibitory concentration: 12900 nM
Beside the measured number, compound 4's estimate is 1.6-fold (0.19 log units) above it; the measured number falls inside the stated range.
By their numbers in this assay, from the lowest: compounds 4, 3 and 2 (each within the scatter of the next, the first and the last beyond it). At a limit, above all of these: compound 1.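

The aryl on the ring nitrogen now has its first measured step in this assay: a 1.6-fold lower number from compound 3 to compound 4 (0.20 log units; within the scatter), for 3-methoxyphenyl in place of 2-methylphenyl on a nitrogen on an aromatic ring. This exchange brings in an oxygen and a hydrogen-bond acceptor, yet no order can be read between the two compounds, so the position holds either aryl without a readable change on this read-out. Nothing available bears on the cause of this step.

Going by these compounds, whether an amine, a carboxylic acid or a longer chain such as butoxy on this aryl would give a step beyond the scatter remains open, as does whether the same exchange would read alike with a different aryl on the amide-type nitrogen. Compound 2 differs from compound 3 and compound 4 in more than one place, so the effect of each aryl alone, and of the further group carried by compound 3 and compound 4 on their amide-side aryl, also remains unresolved.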